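This account rests on a few compounds, and the source may have more. Where it says the series, first, only, none or still open, it means among the compounds named here.

Values so far in a functional assay on KB 3-1 cells (Homo sapiens) for cytotoxicity, read by MTT assay, with a stated time of 72 h; on this read-out lower numbers stand for stronger inhibition and higher numbers for weaker inhibition

- compound 1 (`O=C1Nc2ccccc2/C1=N/NC(=S)NC1CCCCC1`) with 9140 nM
- compound 2 (`C=CCNC(=S)N/N=C1\C(=O)Nc2ccccc21`) with 26100 nM
- compound 3 (`CC(C)NC(=S)N/N=C1\C(=O)Nc2ccccc21`) with 39300 nM

Compound 3 belongs to the upper pair of these numbers. The step inside that pair (a 1.5-fold higher number from compound 2 to compound 3 (0.18 log units; within the scatter)) lies within the scatter. Within the data shown here, the only steps beyond the scatter are the two that leave the cyclohexyl group (a 4.3-fold higher number from compound 1 to compound 3 (0.63 log units; beyond the scatter) and a 2.9-fold higher number from compound 1 to compound 2 (0.46 log units; beyond the scatter)), and both are modest.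

The next compound is compound 4 (`CNC(=S)N/N=C1\C(=O)Nc2ccccc21`), with methyl in place of isopropyl on an amide-type nitrogen. Among the measured compounds shown here, no measured step involves methyl, so the three steps above are only indirect guides. Leaving cyclohexyl raised the number modestly, while exchanging allyl for isopropyl gave no change beyond the scatter. In this assay a small rise is therefore expected, probably not beyond the scatter, and a drop would be a surprise on these three compounds. The expected step is a 1.2-fold higher number from compound 3 to compound 4 (0.09 log units; within the scatter) and the estimate stays wide. It rests on so few data. Compound 4 is expected at 48000 nM (estimated range 22000 nM to 105000 nM).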

Compound 4, half-maximal inhibitory concentration: 35300 nM
Compound 4: middle estimate off by 1.4-fold (0.13 log units), on the high side; the measured number falls inside the stated range.
By their numbers in this assay, from the lowest: compound 1; then compounds 2, 4 and 3 (each within the scatter of the next).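

In this assay, cutting the substituent on the amide-type nitrogen from isopropyl to methyl gives a 1.1-fold lower number from compound 3 to compound 4 (0.05 log units; within the scatter), so this change leaves the number within the scatter. Methyl set against allyl reads the same, with a 1.4-fold higher number from compound 2 to compound 4 (0.13 log units; within the scatter), and the methyl, isopropyl and allyl compounds therefore form one group of numbers in which no order can be read, with no exception among them. Methyl in place of cyclohexyl gives a 3.9-fold higher number from compound 1 to compound 4 (0.59 log units; beyond the scatter), a third modest step beyond the scatter on leaving cyclohexyl, which makes compound 1 the only one of the four that stands apart at this position, though the separation remains small.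

Nothing measured here bears on why cyclohexyl differs from the three smaller groups. Still open, on these data alone, is whether the lower number of compound 1 stays with other rings such as cyclopentyl or phenyl, appears with a longer open chain such as hexyl, or changes when a chain carries an amine or a carboxylic acid.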